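Benzyl in Place of Pentan-3-yl on the Chain Carbon

The source may hold more compounds than are shown below. What is called first, only, known or untested is meant among the compounds shown, and "the series" means these compounds.

Compound 1 `CC(C)/C(=C1\C(=O)NC(=O)N1C)c1ccc(-c2ccc3cccc(F)c3c2)[nH]c1=O` gives 85 nM in an assay on membranes from Chem-1 cells for displacement of a labelled ligand from prostaglandin E2 receptor EP3 subtype (Homo sapiens), read by scintillation counting, with a stated time of 2 h; on this read-out lower numbers stand for stronger inhibition and higher numbers for weaker inhibition.
Compound 2 `O=C1NC(=O)/C(=C/C(c2ccc(-c3ccc4cccc(F)c4c3)[nH]c2=O)C2CC2)O1` gives 22 nM in this assay.
Compound 3 `CCC(CC)C(/C=C1\OC(=O)NC1=O)c1ccc(-c2ccc3cccc(F)c3c2)[nH]c1=O` gives 13 nM in this assay.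

Among these three, compound 3 shows the lowest number; compound 2 lies within the scatter of it, whereas compound 1 stands beyond the scatter above it. For the measured compounds named here, the one measured pair that differs in a single place gives a 1.7-fold lower number from compound 2 to compound 3 (0.23 log units; within the scatter), a step that did not move the number beyond the scatter.

Compound 4 `O=C1NC(=O)/C(=C/C(Cc2ccccc2)c2ccc(-c3ccc4cccc(F)c4c3)[nH]c2=O)O1` has not yet been measured. It differs from compound 3 in one place: benzyl in place of pentan-3-yl on a saturated chain carbon bound to an aromatic carbon and a double-bonded chain carbon. Going by the values given here, no measured pair exchanges benzyl for any other group on this saturated chain carbon, so the only step that bears on the change is the one already named, and it was small. For compound 4 the expected step in this assay is a 1.5-fold higher number from compound 3 to compound 4 (0.19 log units; within the scatter), that is, nothing beyond the scatter in either direction. This expectation rests on the fact that a 1.7-fold lower number from compound 2 to compound 3 (0.23 log units; within the scatter) stayed within the scatter when one group replaced another at the same place. Compound 4 is therefore estimated at 20 nM, with a range from 8 nM to 50 nM.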

Compound 4, inhibition constant in the prostaglandin E2 receptor EP3 subtype assay: 33 nM
Compound 4: middle estimate off by 1.7-fold (0.22 log units), on the low side, and the stated range covers the measured number.
By their numbers in the prostaglandin E2 receptor EP3 subtype assay, from the lowest: compounds 3, 2 and 4 (each within the scatter of the next, the first and the last beyond it); then compound 1.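

In the prostaglandin E2 receptor EP3 subtype assay, the exchange at this saturated chain carbon now gives a step beyond the scatter, though a modest one: a 2.5-fold higher number from compound 3 to compound 4 (0.40 log units; beyond the scatter). Cyclopropyl does not separate from benzyl in the same way, since a 1.5-fold higher number from compound 2 to compound 4 (0.18 log units; within the scatter), so the three groups form a short series in which only pentan-3-yl and benzyl, at its two ends, lie beyond the scatter of each other. The exchange also reaches a second read-out, for in a physicochemical assay for solubility, measured as kinetic solubility, at pH 2 (on this read-out lower numbers stand for lower solubility and higher numbers for higher solubility), compound 3 gives 3680 nM and compound 4 gives 900 nM, which shows that benzyl in place of pentan-3-yl lowers solubility as well as weakening the number in the prostaglandin E2 receptor EP3 subtype assay: the measured solubility of compound 3, 3680 nM, and of compound 4, 900 nM, a 4.1-fold lower number (0.61 log units; beyond the scatter)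

On these data alone, with only cyclopropyl, pentan-3-yl and benzyl on this carbon, it stays open how a group carrying an amine or a carboxylic acid would fare in the prostaglandin E2 receptor EP3 subtype assay and in the physicochemical assay. Nor can this single pair, read in both assays, separate the aromatic ring of benzyl from its larger count of heavy atoms as the feature that goes with these shifts.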